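Compound 3 to compound 4: fluoro in place of bromo

The source may report more compounds than this note shows. Statements on the series, on what has been measured and on what is new or still open speak of the compounds shown alone.

In a functional assay on KYSE-70 cells for antiproliferative activity against KYSE-70 cell line (Homo sapiens), read by MTT assay, with a stated time of 72 h (a higher number here means a weaker inhibitor, a lower number a stronger inhibitor), compound 1 (`O=C(Nc1ccc(Cl)cc1)c1ccnc2cc(Br)ccc12`) gives > 20000 nM, which is a limit and not a number. Compound 2 (`O=C(Nc1cc(F)c(F)c(F)c1)c1cc(=O)[nH]c2cc(Br)ccc12`) gives > 20000 nM, again a limit. Going by the values given here, compound 3 (`O=C(Nc1cc(F)cc(F)c1)c1cc(=O)[nH]c2cc(Br)ccc12`) gives 10700 nM, the only true number so far. The other two readings share one ceiling, (the limit of > 20000 nM in this assay, at which 2 of the 3 values shown sit).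

Compound 4 (`O=C(Nc1cc(F)cc(F)c1)c1cc(=O)[nH]c2cc(F)ccc12`) comes from compound 3 by a single exchange on the shared core: fluoro in place of bromo on an aromatic carbon. The bromo leaves an aromatic carbon and a fluoro takes its place.

Among the compounds with values here, the only measured step is an at least 1.8-fold lower number from compound 2 to compound 3 (0.27 log units; that floor lies within the scatter). It does not touch the bromo, and its floor stays within the scatter, so it gives no size or direction for this exchange. Within the data shown here, no measured step replaces the bromo, and the series offers no evidence for a shift either way. The starting point is therefore compound 3 at 10700 nM, with a wide range around it.

The expected step is a 1.2-fold higher number from compound 3 to compound 4 (0.08 log units; within the scatter), which means no estimated shift beyond the scatter in either direction. A limit reading also remains possible. For compound 4 the estimated value is 13000 nM, with an expected range from 6000 nM to 20000 nM.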

Compound 4, half-maximal inhibitory concentration: > 20000 nM
Compound 4 was reported as a limit; the forecaster's own chance of this, stated with the estimate: 35%; middle value at least 1.5-fold (0.18 log units) from the limit.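

Going by these compounds alone, the exchange of fluoro for bromo is the first change read at this aromatic carbon of the shared core, and in this assay it gives an at least 1.8-fold higher number from compound 3 to compound 4 (0.27 log units; that floor lies within the scatter); with only a floor inside the scatter, this step fixes neither a size nor a firm direction. Compound 4 gives > 20000 nM, which is a limit and not a number. Fluoro at this position therefore yields no reading inside the measured range, compound 3 remains the only compound with a true number, and the series now sits mostly at one ceiling: the limit of > 20000 nM in this assay, at which 3 of the 4 values shown sit.

The compounds shown leave open how far compound 4 actually lies from compound 3, and so whether the exchange of these two halogens matters at all. An amine, a methoxy group or a longer chain on this aromatic carbon would show whether any group here can move the reading clear of that ceiling, and in which direction.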